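From 4-chlorophenyl to 4-hydroxyphenyl: notes on compound 3

This account rests on a few compounds, and the source may have more. Where it says the series, first, only, none or still open, it means among the compounds named here.

In a functional assay on MOLT-4 cells (Homo sapiens) for inhibition, read by MTT assay, with a stated time of 72 h (a lower number here means a stronger inhibitor, a higher number a weaker inhibitor), compound 1 `COc1cc(NC(C)CCCNC(=O)Nc2cccc(O)c2)c2ncccc2c1` gives 24000 nM and compound 2 `COc1cc(NC(C)CCCNC(=O)Nc2ccc(Cl)cc2)c2ncccc2c1` gives 24000 nM. Among the measured compounds shown here, compound 2 therefore stands level with compound 1, its only measured neighbour.

The next compound is compound 3 `COc1cc(NC(C)CCCNC(=O)Nc2ccc(O)cc2)c2ncccc2c1`, and its difference from compound 2 reads: hydroxy in place of chloro on an aromatic carbon. Hydroxy takes the place of chloro on an aromatic carbon, para to a large group, so that 4-chlorophenyl becomes 4-hydroxyphenyl.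

For the measured compounds named here, one measured step bears on this change: no change at the digits printed from compound 1 to compound 2 (within the scatter). That step also connects a hydroxy-bearing phenyl with the 4-chlorophenyl, and it stayed within the scatter. Going by the values given here, it is only a single step, however, and the hydroxy of compound 3 sits at a different position from that of compound 1. Among the compounds with values here, no measured compound carries the 4-hydroxyphenyl group itself.

No step beyond the scatter is therefore expected in this assay, and the estimated change is a 1.0-fold lower number from compound 2 to compound 3 (0.02 log units; within the scatter). For compound 3 the expected value is 23000 nM, with an estimated range of 11000 nM to 48000 nM.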

Compound 3, half-maximal inhibitory concentration: 21000 nM
Estimate against measurement, compound 3: 1.1-fold (0.04 log units) above, within the range that was stated.
By their numbers in this assay, from the lowest: compounds 3, 1 and 2 (each within the scatter of the next).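

In this assay, the exchange of chloro for hydroxy on an aromatic carbon, para to a large group, now has its own measured step (a 1.1-fold lower number from compound 2 to compound 3 (0.06 log units; within the scatter)), so 4-chlorophenyl and 4-hydroxyphenyl read alike here, even though the hydroxy brings a hydrogen-bond donor and a hydrogen-bond acceptor that the chloro lacks. The series also now holds a pair that differs only in where the hydroxy stands on the phenyl ring (a 1.1-fold lower number from compound 1 to compound 3 (0.06 log units; within the scatter)), and 3-hydroxyphenyl and 4-hydroxyphenyl read alike as well, so across these three compounds neither the exchange of group nor the place of the hydroxy separates the values. No measured evidence accounts for this flat reading.

Whether this position can move the number at all stays open, since all three compounds lie within the scatter of one another and an amine, a carboxylic acid or a nitrile on the same ring lies outside the compounds shown. Equally open, on these data alone, is whether a change elsewhere, such as a longer chain between the shared core and the amide-type nitrogen, would separate values where these phenyl changes do not.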